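The source may hold more compounds than are shown below. What is called first, only, known or untested is meant among the compounds shown, and "the series" means these compounds.

In a functional assay on NALM-6 cells (Homo sapiens) for cytotoxicity, with a stated time of 72 h (on this read-out lower numbers stand for an effect already at smaller amounts and higher numbers for an effect only at larger amounts of compound), compound 1 `C=C[C@@](C)(/C=C/c1ccc(OCc2ccccc2)cc1)CCC=C(C)C` gives only a limit, > 43400 nM. Compound 2 `C=C[C@@](C)(/C=C/c1ccc(OS(=O)(=O)C(F)(F)F)cc1)CCC=C(C)C` also gives only a limit, > 43400 nM. Compound 3 `C=C[C@@](C)(/C=C/c1ccc(Nc2ccc(Cl)cc2)cc1)CCC=C(C)C` likewise gives only a limit, > 43400 nM. All three therefore stand together at the limit of > 43400 nM in this assay, at which 3 of the 3 values shown sit, and no number places compound 3 among them.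

Compound 4 `C=C[C@@](C)(/C=C/c1ccc(-c2cccc(Br)c2)cc1)CCC=C(C)C` differs from compound 3 at one aromatic carbon: 3-bromophenyl in place of (4-chlorophenyl)amino on an aromatic carbon. That carbon has changed before, in a step that the two limits leave unreadable from compound 1 to compound 3 and in a step that the two limits leave unreadable from compound 2 to compound 3. Neither gives a size to carry over, so no step beyond the usual scatter is expected. The expected change is a number no higher from compound 3 to compound 4 (the limit leaves the size open). For compound 4 the estimate is 43400 nM, with an expected range from 12000 nM to 60000 nM, and another limit is the likeliest report.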

Compound 4, half-maximal effective concentration: > 43400 nM
Compound 4: only a limit was reported; the forecaster's own chance of this, stated with the estimate: 85%; the middle value lies on the limit itself.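

Among these compounds, compound 4 gives only a limit, as do compound 1, compound 2 and compound 3, so no step among them can be read: the limit of > 43400 nM in this assay, at which 4 of the 4 values shown sit. The compounds shown leave open how these four rank, and whether any group on that aromatic carbon gives a readable number.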